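The compounds below may be only part of what the source reports. "The series", "measured", "known", "first", "only" and "open" are said of these compounds alone.

Working notes on the series. Of the compounds shown here, two have numbers so far. Compound 2 `Oc1ccc(C2CC(c3ccccc3)=NN2c2cccc(Cl)c2)cc1` in an assay on isolated protein for inhibition of protein kinase C iota type (Homo sapiens), tested at 20 uM (on this read-out higher numbers stand for more inhibition at the one concentration tested (going by the name of the read-out) and lower numbers for less inhibition), gives 45.5%; compound 1 `CC(C)(C)C1=NN(c2cccc(Cl)c2)C(c2ccc(O)cc2)C1` in this assay gives 43.5%. Among the measured compounds shown here, the only step between them, a number 2 percentage points higher from compound 1 to compound 2 (within the scatter), is within the scatter, so compound 2 and compound 1 cannot be told apart on these numbers.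

The next compound, compound 3 `Oc1ccc(C2CC(c3ccccn3)=NN2c2cccc(Cl)c2)cc1`, differs from compound 2 by pyridin-2-yl in place of phenyl on a carbon with a double bond to nitrogen. For the measured compounds named here, no measured step exchanges phenyl for pyridin-2-yl; the one step that touches the same carbon, a number 2 percentage points higher from compound 1 to compound 2 (within the scatter), was within the scatter, and that is the only bearing the data have. The expectation for this assay is therefore a step of a number 0.5 percentage points lower from compound 2 to compound 3 (within the scatter), none beyond the scatter, from compound 2 to compound 3. Compound 3 is estimated at 45% in this assay, with a range from 25% to 63%.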

Compound 3, a percentage reported as inhibition, at one concentration (the size of the read-out at that concentration, not a potency): 24.1%
Estimate against measurement, compound 3: 20.9 percentage points above; measured number below the stated range.
By their numbers in this assay, from the lowest: compound 3; then compounds 1 and 2 (each within the scatter of the next).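

The carbon with a double bond to nitrogen is not indifferent to what it carries in this assay: tert-butyl and phenyl could not be told apart there, but pyridin-2-yl gives a number 21.4 percentage points lower from compound 2 to compound 3 (beyond the scatter) and a number 19.4 percentage points lower from compound 1 to compound 3 (beyond the scatter). Phenyl and pyridin-2-yl have the same number of heavy atoms and the same ring size, and pyridin-2-yl differs in a ring nitrogen and a hydrogen-bond acceptor, so a change confined to that ring is enough to move this read-out beyond the scatter. No supporting measurement bears on why the number drops.

Going by these compounds, it stays open how thienyl, cyclohexyl or an aminomethyl group would read on this carbon. Also open, on these data alone, is whether the drop with pyridin-2-yl persists when the 3-chlorophenyl or 4-hydroxyphenyl group is exchanged.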